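Compound 3 to compound 4: pyridin-3-yl on the carbonyl

The source may hold more compounds than are shown below. What is called first, only, known or untested is meant among the compounds shown, and "the series" means these compounds.

In a functional assay on MDA-MB-231 cells (Homo sapiens) for antiproliferative activity, with a stated time of 4 days (a higher number here means a weaker inhibitor, a lower number a stronger inhibitor), compound 1 (`CCCCc1ccc2[nH]c(-c3ccc(OC)cc3)c(/C=N/NC(=O)c3ccc(OC)cc3)c2c1`) gives 61 nM, compound 2 (`CCCCc1ccc2[nH]c(-c3ccc(OC)cc3)c(/C=N/NC(=O)c3cccc(OC)c3)c2c1`) gives 55 nM and compound 3 (`CCCCc1ccc2[nH]c(-c3ccc(OC)cc3)c(/C=N/NC(=O)c3cccc(O)c3)c2c1`) gives 30 nM. Compound 3 stands at the low end of this short series, with a 2.0-fold lower number from compound 1 to compound 3 (0.31 log units; beyond the scatter) and a 1.8-fold lower number from compound 2 to compound 3 (0.26 log units; within the scatter).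

Compound 4 (`CCCCc1ccc2[nH]c(-c3ccc(OC)cc3)c(/C=N/NC(=O)c3cccnc3)c2c1`) carries pyridin-3-yl in place of 3-hydroxyphenyl on a carbonyl carbon. Within the data shown here, no measured compound carries this ring. Among the measured compounds shown here, the steps that bear on it are those two and a 1.1-fold lower number from compound 1 to compound 2 (0.04 log units; within the scatter), all small. A small rise is therefore expected, with the estimated change being a 2.0-fold higher number from compound 3 to compound 4 (0.30 log units; within the scatter). For compound 4 the estimate is 60 nM, with an expected range of 25 nM to 150 nM.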

Compound 4, half-maximal inhibitory concentration: 35 nM
For compound 4 the middle estimate is 1.7-fold (0.23 log units) above the measured one; the measured number falls inside the stated range.
By their numbers in this assay, from the lowest: compounds 3, 4, 2 and 1 (each within the scatter of the next, the first and the last beyond it).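

In this assay, the pyridin-3-yl ring on the carbonyl carbon stays within the scatter of all three phenyl-bearing compounds: a 1.2-fold higher number from compound 3 to compound 4 (0.07 log units; within the scatter), a 1.6-fold lower number from compound 2 to compound 4 (0.20 log units; within the scatter) and a 1.7-fold lower number from compound 1 to compound 4 (0.24 log units; within the scatter). Among these compounds, the earlier compounds carried only six-membered aromatic rings of carbon, so compound 4 is the first to show that a ring nitrogen is accommodated here without a step beyond the scatter. No evidence bearing on the reason for this result is available.

Still open, from the compounds shown here alone, is whether pyridin-2-yl or pyridin-4-yl would match pyridin-3-yl at this place. An amine or a carboxylic acid on this ring also remains untested among the compounds shown.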